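Thienopyrimidine ureas: piperazinylmethyl addition on two cores

The source may report more compounds than this note shows. Statements on the series, on what has been measured and on what is new or still open speak of the compounds shown alone.

Compound 1 `O=C(Nc1ccc(-c2nc(N3CC4CCC(C3)O4)c3sccc3n2)cc1)NC1CC1` gives 40 nM in a functional assay on LNCaP cells (Homo sapiens) for cytotoxicity; on this read-out lower numbers stand for stronger inhibition and higher numbers for weaker inhibition. Compound 2 `CS(=O)(=O)N1CCN(Cc2cc3nc(-c4ccc(NC(=O)NC5CC5)cc4)nc(N4CC5CCC(C4)O5)c3s2)CC1` differs from it by (4-(methylsulfonyl)piperazin-1-yl)methyl in place of hydrogen on an aromatic carbon, and in this assay compound 2 gives 32 nM; the step is a 1.3-fold lower number from compound 1 to compound 2 (0.10 log units; within the scatter). Compound 3 `O=C(Nc1ccncc1)Nc1ccc(-c2nc(N3CC4CCC(C3)O4)c3sccc3n2)cc1` differs from compound 1 by pyridin-4-yl in place of cyclopropyl on an amide-type nitrogen; in this assay compound 3 gives 10 nM, a step of a 4.0-fold lower number from compound 1 to compound 3 (0.60 log units; beyond the scatter), leaving compound 3 with the lowest number of the three measured. Compound 4 `CS(=O)(=O)N1CCN(Cc2cc3nc(-c4ccc(NC(=O)Nc5ccncc5)cc4)nc(N4CC5CCC(C4)O5)c3s2)CC1` is not yet measured; it differs from compound 3 by (4-(methylsulfonyl)piperazin-1-yl)methyl in place of hydrogen on an aromatic carbon, the same change as from compound 1 to compound 2, at the same place, but on the core of compound 3. Because a 1.3-fold lower number from compound 1 to compound 2 (0.10 log units; within the scatter) was within the scatter, a similar step is expected here, estimated as a 1.3-fold lower number from compound 3 to compound 4 (0.10 log units; within the scatter). Compound 4 is therefore expected to give about 8 nM, with a range from 4 nM to 18 nM.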

Compound 4, half-maximal inhibitory concentration: 120 nM
Estimate against measurement, compound 4: 15-fold (1.18 log units) below, outside the stated range (above it).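

With the pyridin-4-yl urea, (4-(methylsulfonyl)piperazin-1-yl)methyl next to the ring sulfur gives a 12-fold higher number from compound 3 to compound 4 (1.08 log units; beyond the scatter), so the step seen with the cyclopropyl urea does not carry over in this assay: the same change on two cores in this assay, a 1.3-fold lower number (0.10 log units; within the scatter) from compound 1 to compound 2 and a 12-fold higher number (1.08 log units; beyond the scatter) from compound 3 to compound 4, 15-fold (1.18 log units) apart, beyond the scatter of two such steps. Likewise, with that group present, pyridin-4-yl in place of cyclopropyl gives a 3.8-fold higher number from compound 2 to compound 4 (0.57 log units; beyond the scatter), opposite in direction to the step without it: the same change on two cores in this assay, a 4.0-fold lower number (0.60 log units; beyond the scatter) from compound 1 to compound 3 and a 3.8-fold higher number (0.57 log units; beyond the scatter) from compound 2 to compound 4, 15-fold (1.18 log units) apart, beyond the scatter of two such steps. The two changes therefore do not add across these four compounds, but a single pair of cores does not show why, or how the group would behave on any other core.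

Still open, from the compounds shown here alone, is whether the rise in the number follows pyridin-4-yl specifically or would also appear with phenyl on the urea. Also open, going by these compounds, is whether it depends on the methylsulfonyl, which a piperazine bearing acetyl or a morpholine in place of the whole piperazine would test.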